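Nitrile to trifluoromethyl swap carried onto a second core

The source may report more compounds than this note shows. Statements on the series, on what has been measured and on what is new or still open speak of the compounds shown alone.

Compound 1 `COc1ccc(-c2ccc3c(c2)C(=O)C(=O)N3Cc2ccc(C#N)cc2)cc1` and compound 2 `COc1ccc(-c2ccc3c(c2)C(=O)C(=O)N3Cc2ccc(C(F)(F)F)cc2)cc1` share one core and differ only at the end of the benzyl arm. Compound 3 `COc1ccc(CN2C(=O)C(=O)c3cc(-c4ccc(C#N)cc4)ccc32)cc1` is built from the same atoms as compound 1, joined differently; the difference between the two cores is not broken down here. Compound 4 `COc1ccc(CN2C(=O)C(=O)c3cc(-c4ccc(C(F)(F)F)cc4)ccc32)cc1` is the unmeasured partner of compound 3.

In a functional assay on K562 cells (Homo sapiens) for antiproliferative activity, read by MTT assay, with a stated time of 48 h (on this read-out higher numbers stand for weaker inhibition and lower numbers for stronger inhibition), compound 1 gives 380 nM. Compound 2 gives 270 nM in this assay. The change from compound 1 to compound 2 is trifluoromethyl in place of cyano on an aromatic carbon, and it produced a 1.4-fold lower number from compound 1 to compound 2 (0.15 log units; within the scatter). In this assay compound 3 gives 260 nM; the values of compound 3 and compound 2 lie within the scatter of each other, and so do those of compound 3 and compound 1, so no order among the three is claimed.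

Compound 4 differs from compound 3 by trifluoromethyl in place of cyano on an aromatic carbon. The place is described in the same words as for the change from compound 1 to compound 2, so this is the same change, now made on the core of compound 3. Among the compounds with values here, the only guide to its effect is that one measured step, which stayed within the scatter.

Compound 4 is therefore expected to move from compound 3 by a 1.4-fold lower number from compound 3 to compound 4 (0.14 log units; within the scatter), and this rests on a 1.4-fold lower number from compound 1 to compound 2 (0.15 log units; within the scatter). In this assay compound 4 is estimated at 190 nM, with a likely range from 100 nM to 380 nM.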

Compound 4, half-maximal inhibitory concentration: 350 nM
Compound 4: middle estimate off by 1.8-fold (0.27 log units), on the low side, and the stated range covers the measured number.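

In this assay, within the data shown here, trifluoromethyl in place of cyano on the core of compound 3 gives a 1.3-fold higher number from compound 3 to compound 4 (0.13 log units; within the scatter), so on this core the swap produces no step that can be told from repeated measurement. Set beside the earlier step, the result gives no sign that the core alters the outcome of this change: the same change on two cores in this assay, a 1.4-fold lower number (0.15 log units; within the scatter) from compound 1 to compound 2 and a 1.3-fold higher number (0.13 log units; within the scatter) from compound 3 to compound 4, 1.9-fold (0.28 log units) apart, within the scatter of two such steps This shows that, on the two cores at hand, nitrile and trifluoromethyl at the end of the molecule are interchangeable within the resolution of this assay, but it does not show a reversal of the effect between cores, since the differing directions of the two steps rest on steps that each stay within the scatter, and it does not show that a larger effect would carry across, since neither pair supplies one.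

Open, from the compounds shown here alone, is whether a group of another kind in the same place, such as an amine or a carboxylic acid, would give a step beyond the scatter on either core. Also open, going by these compounds, is whether a longer chain in place of the benzyl arm would leave this swap just as silent.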